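Trading the nitro ring of compound 3 for methoxy

A few compounds are considered here, and "the series" means these few. Any claim that something is new, unique, unknown or untested is made for them only; others in the source may bear on it.

In a functional assay on MV4-11 cells (Homo sapiens) for antiproliferative activity, read by luminescence and CellTiter-Glo, with a stated time of 72 h (a lower number here means a stronger inhibitor, a higher number a weaker inhibitor), three compounds sharing one core differ only in the ring on a saturated chain carbon bound to an aromatic nitrogen. Compound 1 `CNc1cc(-c2ccc3cnn(Cc4ccc(OC)cc4)c3c2)cn(C)c1=O` gives 2700 nM, compound 2 `CNc1cc(-c2ccc3cnn(Cc4ccc(F)c(F)c4)c3c2)cn(C)c1=O` gives 320 nM, and compound 3 `CNc1cc(-c2ccc3cnn(Cc4ccc(F)c([N+](=O)[O-])c4)c3c2)cn(C)c1=O` gives 130 nM. Compound 3 thus has the lowest number of the three, and its gaps to both others lie beyond the scatter.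

Compound 4 `CNc1cc(-c2ccc3cnn(Cc4ccc(OC)c(F)c4)c3c2)cn(C)c1=O` carries 3-fluoro-4-methoxyphenyl in place of 4-fluoro-3-nitrophenyl (3-fluoro-4-methoxyphenyl in place of 4-fluoro-3-nitrophenyl on a saturated chain carbon bound to an aromatic nitrogen). The nitro group leaves, and a methoxy group enters. For the measured compounds named here, three measured steps bear on this change. Moving away from 4-methoxyphenyl gave a 21-fold lower number from compound 1 to compound 3 (1.32 log units; beyond the scatter) and an 8.4-fold lower number from compound 1 to compound 2 (0.93 log units; beyond the scatter), a large and a modest step. Nitro in place of fluoro gave a smaller one, a 2.5-fold lower number from compound 2 to compound 3 (0.39 log units; beyond the scatter).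

Compound 4 has a methoxy group like compound 1, at 2700 nM, and a fluoro like compound 2, at 320 nM. Going by the values given here, no measured compound has both groups on its ring, so the expectation is a value between those two. The expected change is a 6.2-fold higher number from compound 3 to compound 4 (0.79 log units; beyond the scatter), a modest step towards a weaker inhibitor. Compound 4 is estimated at 800 nM, with an expected range of 250 nM to 2500 nM.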

Compound 4, half-maximal inhibitory concentration: 4980 nM
Compound 4: middle estimate off by 6.2-fold (0.79 log units), on the low side; the whole stated range lies below it.
By their numbers in this assay, from the lowest: compound 3; then compound 2; then compounds 1 and 4 (each within the scatter of the next).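

In this assay, replacing the ring of compound 3 with 3-fluoro-4-methoxyphenyl gives a 38-fold higher number from compound 3 to compound 4 (1.58 log units; beyond the scatter), a larger loss than any earlier step at this position, and it shows that the methoxy group outweighs the fluoro when both sit on the ring. Methoxy in place of fluoro gives a 16-fold higher number from compound 2 to compound 4 (1.19 log units; beyond the scatter), whereas fluoro in place of hydrogen on the methoxy-bearing ring gives only a 1.8-fold higher number from compound 1 to compound 4 (0.27 log units; within the scatter), so the added fluoro does not bring compound 4 closer to compound 2, and the two compounds with a methoxy group stay together at the weak end of this small set. Nothing measured here explains why the methoxy group goes with these higher numbers.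

The compounds shown leave open whether the loss is specific to methoxy, or whether another group in its place, such as an amine or a nitrile, would keep compound 4 closer to compound 2 or compound 3. They also leave open whether a longer chain between the ring and the aromatic nitrogen would change how much these ring groups matter.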